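Notes on the amide-nitrogen substituent of compound 2

This account rests on a few compounds, and the source may have more. Where it says the series, first, only, none or still open, it means among the compounds named here.

Measured so far:
compound 1, `Cc1c(C(=O)Nc2ccc(C(F)(F)F)cc2)cnn1-c1ccc(F)c(Cl)c1`, 1300 nM
compound 2, `Cc1c(C(=O)Nc2cccc(F)c2)cnn1-c1ccc(F)cc1`, 3000 nM

Both were run in a functional assay with Homo sapiens as the target; a lower number here means a stronger inhibitor, a higher number a weaker inhibitor. Compound 2 gives 3000 nM, the highest of the two numbers; compound 1 gives the lower number, and the gap between them lies beyond the usual scatter. The two compounds differ in more than one place, so the gap cannot be assigned to any single change.

Compound 3, `CCCCC(CC)NC(=O)c1cnn(-c2ccc(F)cc2)c1C`, has not been measured. It differs from compound 2 in one place: 1-ethylpentyl in place of 3-fluorophenyl on an amide-type nitrogen. Within the data shown here, no pair among the measured compounds shows what this change does on its own; the only comparison available involves changes in two places at once.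

With nothing to anchor the step, the expectation is a modest move toward a higher number, of a size that may or may not exceed the scatter. Compound 3 is estimated at 5000 nM, with a range from 1500 nM to 16000 nM. The step that this estimate implies, a 1.7-fold higher number from compound 2 to compound 3 (0.22 log units; within the scatter), is expected to be small relative to the uncertainty around it.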

Compound 3, half-maximal inhibitory concentration: 580 nM
Beside the measured number, compound 3's estimate is 8.6-fold (0.94 log units) above it; measured number below the stated range.
By their numbers in this assay, from the lowest: compound 3; then compound 1; then compound 2.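

At the amide-type nitrogen, 1-ethylpentyl in place of 3-fluorophenyl gives, in this assay, a 5.2-fold lower number from compound 2 to compound 3 (0.71 log units; beyond the scatter). Among these compounds, this is the only single-place step so far, and it shows that this position affects the read-out on its own, a point the two earlier compounds could not settle because they differ in more than one place. For this pair, an aromatic ring on the nitrogen is not needed: compound 3 has a ring-free group in that place and still gives 580 nM, though no measurement at hand speaks to the origin of the step.

Going by these compounds, whether the same replacement would hold with the other groups carried by compound 1 remains open. Also open, on these data alone, is which feature of 1-ethylpentyl matters, since a shorter chain such as n-butyl, an unbranched longer chain such as n-heptyl, or a saturated ring such as cyclohexyl on the same nitrogen would separate branching, chain length and loss of the aromatic ring.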